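Second methoxy on the aryl ring of compound 3

The source may hold more compounds than are shown below. What is called first, only, known or untested is meant among the compounds shown, and "the series" means these compounds.

Compound 3 `CCOc1nc(-c2cc3ccccc3o2)cc(-c2ccc(OC)cc2)c1C#N` gives 204000 nM in a functional assay on aorta (strain Wistar) for inhibition, with Thoracic aorta (Rattus norvegicus) as the target; on this read-out lower numbers stand for stronger inhibition and higher numbers for weaker inhibition. Compound 1 `CCOc1nc(-c2cc3ccccc3o2)cc(-c2cccc3ccccc23)c1C#N` gives 344000 nM and compound 2 `CCOc1nc(-c2cc3ccccc3o2)cc(-c2ccc(F)cc2)c1C#N` gives 396000 nM; the steps of a 1.7-fold lower number from compound 1 to compound 3 (0.23 log units; within the scatter) and a 1.9-fold lower number from compound 2 to compound 3 (0.29 log units; within the scatter) both stay within the scatter, so compound 3 is not separated from either neighbour on this read-out. Compound 4 `CCOc1nc(-c2cc3ccccc3o2)cc(-c2ccc(OC)cc2OC)c1C#N` differs from compound 3 by methoxy in place of hydrogen on an aromatic carbon. Within the data shown here, no measured pair adds a methoxy to an otherwise unchanged ring; the nearest step, a 1.9-fold lower number from compound 2 to compound 3 (0.29 log units; within the scatter), trades a small group for a methoxy and stays within the scatter, as does a 1.2-fold higher number from compound 1 to compound 2 (0.06 log units; within the scatter). A step of no more than the scatter is therefore expected in this assay. For compound 4 the estimate is 200000 nM, range 80000 nM to 500000 nM, an expected step of a 1.0-fold lower number from compound 3 to compound 4 (0.01 log units; within the scatter).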

Compound 4, half-maximal inhibitory concentration: 488000 nM
Beside the measured number, compound 4's estimate is 2.4-fold (0.39 log units) below it, and the stated range covers the measured number.
By their numbers in this assay, from the lowest: compounds 3, 1, 2 and 4 (each within the scatter of the next, the first and the last beyond it).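

In this assay, among these compounds, methoxy in place of hydrogen, ortho to a large group and meta to a methoxy group, gives a 2.4-fold higher number from compound 3 to compound 4 (0.38 log units; beyond the scatter), the only step so far beyond the scatter, so this ring position is not indifferent to substitution. Compound 4 remains unseparated from the other two aryl variants: a 1.2-fold higher number from compound 2 to compound 4 (0.09 log units; within the scatter) and a 1.4-fold higher number from compound 1 to compound 4 (0.15 log units; within the scatter). Nothing available accounts for the step.

Still open, as far as these compounds go, is whether a 2-methoxyphenyl group without the second methoxy gives a similar step. Also open, from the compounds shown here alone, is how an amine or a carboxylic acid behaves at this position.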